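Dropping one trifluoromethyl group: compound 3 to compound 4

The source may report more compounds than this note shows. Statements on the series, on what has been measured and on what is new or still open speak of the compounds shown alone.

Three compounds of this series have been run in a functional assay on K562 cells (Homo sapiens) for inhibition, read by sulforhodamine B assay, with a stated time of 48 h, tested at 0.1 uM; on this read-out lower numbers stand for a stronger effect and higher numbers for a weaker effect at the one concentration tested. Compound 1 `O=C(Nc1cccc(-n2cc(-c3ccncc3)c(-c3cc(O)cc(Cl)c3)n2)c1)Nc1ccc(Cl)c(C(F)(F)F)c1` gives 94%; compound 2 `O=C(Nc1cccc(-n2cc(-c3ccncc3)c(-c3cc(O)cc(Cl)c3)n2)c1)Nc1ccc(Cl)c(Cl)c1` gives 100%; compound 3 `COc1cc(Cl)cc(-c2nn(-c3cccc(NC(=O)Nc4cc(C(F)(F)F)cc(C(F)(F)F)c4)c3)cc2-c2ccncc2)c1` gives 91%. Compound 3 sits at the low end of the three numbers, yet both of the others lie within the scatter of it, compound 1 being the nearer and compound 2 the further. Within the data shown here, the one step that can be read across two measured compounds is a number 6 percentage points higher from compound 1 to compound 2 (within the scatter), an exchange of one aromatic substituent for another that left this assay unchanged within the scatter.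

Compound 4 `COc1cc(Cl)cc(-c2nn(-c3cccc(NC(=O)Nc4cccc(C(F)(F)F)c4)c3)cc2-c2ccncc2)c1` follows from compound 3 by hydrogen in place of trifluoromethyl on an aromatic carbon. The change sits on the same aromatic carbon type as the exchange between compound 1 and compound 2, although there a group was swapped for another group, whereas here a group is removed outright. Among the measured compounds shown here, with all three measured numbers near the top of the scale and the only comparable step within the scatter, no step beyond the scatter is expected; the estimated step is a number 2 percentage points higher from compound 3 to compound 4 (within the scatter). Compound 4 is therefore expected to give about 93%, in a range from 83% to 103%.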

Compound 4, a percentage reported as activity, at one concentration (the size of the read-out at that concentration, not a potency): 94%
Compound 4: middle estimate off by 1 percentage points, on the low side; the measured number falls inside the stated range.
By their numbers in this assay, from the lowest: compounds 3, 1, 4 and 2 (each within the scatter of the next).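

In this assay, the removal of one trifluoromethyl group gives a number 3 percentage points higher from compound 3 to compound 4 (within the scatter), so this aromatic carbon tolerates the loss of the group, with hydrogen in its place, without a change in the read-out beyond the scatter. The earlier step on an aromatic carbon covered only the exchange of one substituent for another, whereas this pair shows that the 4 heavy atoms of a trifluoromethyl group can leave outright, on a six-membered aromatic ring of carbon only that keeps a second trifluoromethyl group, with no change beyond the scatter at this single concentration. No accompanying measurement bears on the reason for this result.

The compounds shown leave open whether a group of a different kind on this carbon, such as an amine or a carboxylic acid, would shift the read-out beyond the scatter, and whether replacing the remaining trifluoromethyl group with hydrogen would do so. They also leave open whether compound 3 and compound 4 would remain alike at a higher concentration, where a larger effect might allow the two to be told apart.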